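A few compounds are considered here, and "the series" means these few. Any claim that something is new, unique, unknown or untested is made for them only; others in the source may bear on it.

Compound 1 `CC(C)CC1(O)CCN(C(=O)Nc2cc(Oc3ccc(C(=O)O)cc3)cc(Oc3ccc(F)cc3F)c2)CC1`: 18.5 nM
Compound 2 `CC(C)CC1(O)CCN(C(=O)Nc2cc(Oc3ccc(F)cc3)cc(Oc3ccc(CC(=O)O)cc3)c2)CC1`: 237 nM

In an ADME assay on the whole organism for pharmacokinetics, with Rattus norvegicus as the target, at a dose of 1 mg/kg by the oral route (on this read-out higher numbers stand for higher exposure at the dose given and lower numbers for lower exposure), compound 2 gives 237 nM, the highest of the two numbers measured. Among the measured compounds shown here, the nearest, compound 1, gives 18.5 nM, and the gap between the two lies beyond the usual scatter; no step between them is worked out, so only their two values stand. Compound 3 `CC(C)CC1(O)CCN(C(=O)Nc2cc(Oc3ccc(F)cc3)cc(Oc3ccc(C(C)(C)C(=O)O)cc3)c2)CC1` has not yet been measured in this assay. It differs from compound 2 in one place: 1-carboxy-1-methylethyl in place of carboxymethyl on an aromatic carbon, on an aromatic carbon of a six-membered aromatic ring of carbon only, para to a large group. For the measured compounds named here, no measured pair shows this change, so its size and direction are unknown. With compound 2 as the only anchor, for compound 3 the expected step is a 1.1-fold higher number from compound 2 to compound 3 (0.02 log units; within the scatter), none beyond the scatter. Compound 3 is therefore estimated at 250 nM, with a range from 80 nM to 750 nM.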

Compound 3, maximal plasma concentration: 156 nM
Beside the measured number, compound 3's estimate is 1.6-fold (0.20 log units) above it; the measured number falls inside the stated range.
By their numbers in this assay, from the lowest: compound 1; then compounds 3 and 2 (each within the scatter of the next).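

In this assay, putting 1-carboxy-1-methylethyl in place of carboxymethyl on the aromatic carbon para to a large group gives a 1.5-fold lower number from compound 2 to compound 3 (0.18 log units; within the scatter). Among the compounds shown here, this is the first single-place comparison at this position, and it shows that the larger group, with 6 heavy atoms against 4, leaves the maximal plasma concentration within the scatter. Nothing available here bears on the reason for this outcome.

The compounds shown leave open whether the position would tolerate other groups in the same way, such as the longer 2-carboxyethyl chain, the ring-bearing 1-carboxycyclopropyl or a tetrazole. They also leave open whether this change would give a similar step on a core carrying other substituents on the second aryl ether, such as a chlorine atom in place of the fluorine.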